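Isopropyl on the Aniline Nitrogen, Tried on a Second Core

The source may report more compounds than this note shows. Statements on the series, on what has been measured and on what is new or still open speak of the compounds shown alone.

Measured compounds in a functional assay on the whole organism with Rattus norvegicus as the target; a higher number here means a weaker inhibitor, a lower number a stronger inhibitor:
compound 1 `Cc1ccc(O)c(NCCCN2CCN(C(c3ccc(Cl)cc3)c3ccc(Cl)cc3)CC2)c1` gives 0.48 ug/mL
compound 2 `Cc1ccc(O)c(N(CCCN2CCN(C(c3ccc(Cl)cc3)c3ccc(Cl)cc3)CC2)C(C)C)c1` gives 2.2 ug/mL
compound 3 `Cc1ccc(O)c(NCCCN2CCC(C(O)(c3ccccc3)c3ccc(Cl)cc3)CC2)c1` gives 0.041 ug/mL

Compound 3 is the strongest inhibitor of the three; how its core differs from that of compound 1 is not broken down here. Within the core of compound 1, the change isopropyl in place of hydrogen on a nitrogen on an aromatic ring produced a 4.6-fold higher number from compound 1 to compound 2 (0.66 log units; beyond the scatter). Compound 4 `Cc1ccc(O)c(N(CCCN2CCC(C(O)(c3ccccc3)c3ccc(Cl)cc3)CC2)C(C)C)c1` carries the same change on the core of compound 3: isopropyl in place of hydrogen on a nitrogen on an aromatic ring. The surroundings of the changed nitrogen are described in the same words for both pairs, so this counts as the same change. The expectation for compound 4 therefore rests on compound 1 and the step of a 4.6-fold higher number from compound 1 to compound 2 (0.66 log units; beyond the scatter), and a step of about a 4.6-fold higher number from compound 3 to compound 4 (0.67 log units; beyond the scatter) is expected in this assay. Compound 4 is estimated at 0.19 ug/mL, expected between 0.06 ug/mL and 0.6 ug/mL.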

Compound 4, half-maximal inhibitory concentration: 1 ug/mL
Compound 4: the middle estimate sits 5.3-fold (0.72 log units) below what was measured; measured number outside the range, above it.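

In this assay the isopropyl change gave a 24-fold higher number from compound 3 to compound 4 (1.39 log units; beyond the scatter), so the number rose on the core of compound 3, as it had on the core of compound 1. The direction of the step carried over from one core to the other, but its size did not: the same change on two cores in this assay, a 4.6-fold higher number (0.66 log units; beyond the scatter) from compound 1 to compound 2 and a 24-fold higher number (1.39 log units; beyond the scatter) from compound 3 to compound 4, 5.3-fold (0.73 log units) apart, beyond the scatter of two such steps

Among these compounds, with only two pairs, this does not show why the cores respond differently, nor how large the step would be on any further core. In the compounds shown, this nitrogen carries only hydrogen or isopropyl. As far as these compounds go, it remains open whether a methyl or an ethyl group there would also raise the number on both cores, and whether those steps would differ in size as well.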